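The source may hold more compounds than are shown below. What is called first, only, known or untested is meant among the compounds shown, and "the series" means these compounds.

Measured so far in a functional assay on A549 cells (Homo sapiens) for cytotoxicity, read by MTT assay, with a stated time of 72 h; on this read-out lower numbers stand for stronger inhibition and higher numbers for weaker inhibition:
- compound 1 `COc1ncc(-c2ccc3nccc(-c4ccc(Cn5cncn5)cc4)c3c2)cc1NS(=O)(=O)c1ccc(F)cc1F`: 16 nM
- compound 2 `CN(C)Cc1ccc(-c2ccnc3ccc(-c4cnc(Cl)c(NS(=O)(=O)c5ccc(F)cc5F)c4)cc23)cc1`: 251 nM
- compound 3 `O=S(=O)(Nc1cc(-c2ccc3nccc(-c4ccc(Cn5cncn5)cc4)c3c2)cnc1Cl)c1ccc(F)cc1F`: 642 nM

Compound 3 stands at the top of these three numbers, meaning it is the weakest inhibitor of the set. Its distance from compound 1 is large: a 40-fold higher number from compound 1 to compound 3 (1.60 log units; beyond the scatter). Its distance from compound 2 is modest: a 2.6-fold higher number from compound 2 to compound 3 (0.41 log units; beyond the scatter).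

Compound 4 `O=S(=O)(Nc1cc(-c2ccc3nccc(-c4ccc(Cn5cncn5)cc4)c3c2)cnc1Cl)c1ccc(F)cc1` differs from compound 3 in one place only: hydrogen in place of fluoro on an aromatic carbon. Neither of the two measured steps touches this sulfonyl-bearing ring; one changes the group on the shared core, the other the group on the saturated chain carbon. No measured comparison therefore bears directly on removing this fluoro, and the data give no ground to expect a shift beyond the scatter in this assay in either direction. The expected step is a 1.2-fold higher number from compound 3 to compound 4 (0.10 log units; within the scatter), set close to no change. Compound 4 is accordingly estimated at 800 nM, with a range from 300 nM to 2500 nM.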

Compound 4, half-maximal inhibitory concentration: 178 nM
Compound 4: the middle estimate sits 4.5-fold (0.65 log units) above what was measured, outside the stated range (below it).
By their numbers in this assay, from the lowest: compound 1; then compounds 4 and 2 (each within the scatter of the next); then compound 3.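

Removing one fluoro from the ring on the sulfonyl group, turning 2,4-difluorophenyl into 4-fluorophenyl, gives a 3.6-fold lower number from compound 3 to compound 4 (0.56 log units; beyond the scatter) in this assay. For the compounds shown here, this is the first measured change on this ring, and it shows that this aromatic carbon, ortho to a large group, affects the read-out even though only a single heavy atom leaves. Here the compound with hydrogen at this position gives the lower number, so in this chloro, triazole-bearing series the fluoro is not needed for a low number, though nothing given here explains the shift.

The compounds shown leave open whether hydrogen in place of this fluoro would lower the number in the same way with the methoxy group of compound 1 or the dimethylamino group of compound 2. They also leave open how a methyl group or an amine would behave on this same carbon.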